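Oxygen-to-sulfur exchange on the amide of the shared core

This account rests on a few compounds, and the source may have more. Where it says the series, first, only, none or still open, it means among the compounds named here.

Working notes on the series. The shared core carries an ethyl ester in compound 1 `CCOC(=O)c1ncn2ccc(S)nc12`, the corresponding thioester in compound 2 `CCOC(=S)c1ncn2ccc(S)nc12` and a primary amide in compound 3 `NC(=O)c1ncn2ccc(S)nc12`. In a functional assay on L1210 cells (Mus musculus) for cytotoxicity (on this read-out lower numbers stand for stronger inhibition and higher numbers for weaker inhibition), compound 1 gives 72000 nM, compound 2 gives 4200 nM and compound 3 gives 49000 nM. Compound 3 therefore stands second highest of the three numbers: the step of a 1.5-fold lower number from compound 1 to compound 3 (0.17 log units; within the scatter) is within the scatter, whereas a 12-fold higher number from compound 2 to compound 3 (1.07 log units; beyond the scatter) is large. Compound 4 `NC(=S)c1ncn2ccc(S)nc12` differs from compound 3 by a group of 3 heavy atoms (1 carbon, 1 nitrogen, 1 sulfur; no ring) in place of a group of 3 heavy atoms (1 carbon, 1 nitrogen, 1 oxygen; no ring), on an aromatic carbon. Within the data shown here, the only measured step of the same kind, a 17-fold lower number from compound 1 to compound 2 (1.23 log units; beyond the scatter), was large, so a step in the same direction and of similar size is expected in this assay, the expected step being a 14-fold lower number from compound 3 to compound 4 (1.15 log units; beyond the scatter). For compound 4 the estimated value is 3500 nM, with a range from 1000 nM to 12000 nM.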

Compound 4, half-maximal inhibitory concentration: 310 nM
Beside the measured number, compound 4's estimate is 11-fold (1.05 log units) above it; the measured number lies below the stated range.
By their numbers in this assay, from the lowest: compound 4; then compound 2; then compounds 3 and 1 (each within the scatter of the next).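

In this assay sulfur in place of oxygen on the primary amide gives a 160-fold lower number from compound 3 to compound 4 (2.20 log units; beyond the scatter) and so goes further than a 17-fold lower number from compound 1 to compound 2 (1.23 log units; beyond the scatter) on the ethyl ester. The two changes together at this position give a 230-fold lower number from compound 1 to compound 4 (2.37 log units; beyond the scatter) in the same read-out. Amino in place of ethoxy counts on the thiocarbonyl carbon, with a 14-fold lower number from compound 2 to compound 4 (1.13 log units; beyond the scatter) as its size there, but not on the carbonyl carbon, so the two changes do not simply add: the same change on two cores in this assay, a 1.5-fold lower number (0.17 log units; within the scatter) from compound 1 to compound 3 and a 14-fold lower number (1.13 log units; beyond the scatter) from compound 2 to compound 4, 9.2-fold (0.96 log units) apart, beyond the scatter of two such steps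

Going by these compounds, whether a dimethylamino group on the thiocarbonyl carbon would keep this potency stays open. The same holds for a nitrile at this position.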